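The compounds below may be only part of what the source reports. "The series", "measured", "known", "first", "only" and "open" are said of these compounds alone.

In an ADME assay on HEK-293T cells (Homo sapiens) for cytotoxicity, read by luminescence, with a stated time of 24 h (a higher number here means that more compound is tolerated, a lower number that less compound is tolerated), compound 1 (`COc1ccc(Cn2c(C(N)=O)cc3sccc32)cc1`) gives > 100000 nM as a limit of the assay and not a number. For the measured compounds named here, compound 2 (`CCOC(=O)C1CCN(C(=O)c2cc3sccc3n2Cc2ccc(OC)cc2)CC1`) gives 39000 nM and so holds the only actual number so far, with no other number to rank it against. Compound 3 (`COc1ccc(Cn2c(C(=O)N3CCC(C(=O)NC(C)c4ccccc4)CC3)cc3sccc32)cc1`) keeps the shared core of compound 2 and differs in one place ((1-phenylethyl)amino in place of ethoxy on a carbonyl carbon), with (1-phenylethyl)amino in place of ethoxy on a carbonyl carbon. Going by the values given here, no measured step covers such a change, so the expectation in this assay rests on compound 2 at 39000 nM alone, and no shift beyond the scatter is expected. The expected step is a 1.3-fold lower number from compound 2 to compound 3 (0.11 log units; within the scatter) on this estimate. For compound 3 the estimated half-maximal cytotoxic concentration is 30000 nM with an expected range from 9000 nM to 90000 nM as the working figures.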

Compound 3, half-maximal cytotoxic concentration: > 100000 nM
Compound 3: no number, only a limit; the forecaster's own chance of this, stated with the estimate: 15%; middle value at least 3.3-fold (0.52 log units) from the limit.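

For the compounds shown here, on a carbonyl carbon whose other neighbour is a saturated ring carbon, (1-phenylethyl)amino in place of ethoxy gives the first readable step: in this assay there is an at least 2.5-fold higher number from compound 2 to compound 3 (0.40 log units; beyond the scatter). The change from ethoxycarbonyl to (1-phenylethyl)carbamoyl, which brings in an aromatic ring and a hydrogen-bond donor, therefore moves the number up and not down in this assay. The full size of the step stays open because compound 3 sits at a limit and not at a number: the limit of > 100000 nM in this assay, at which 2 of the 3 values shown sit.

The compounds shown do not separate the contribution of the phenyl ring from that of the amide hydrogen. A simple amine such as dimethylamino or a hydroxyl on the same carbonyl carbon, giving a small amide or a carboxylic acid, would bear on that question.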